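Bis-benzyl Ether of Compound 1: Working Notes

A few compounds are considered here, and "the series" means these few. Any claim that something is new, unique, unknown or untested is made for them only; others in the source may bear on it.

Compound 1 `C=CCc1ccc(OCc2ccccc2)c(-c2ccc(O)c(CC=C)c2)c1`: 21800 nM
Compound 2 `C=CCc1ccc(OCc2ccc(Cl)cc2Cl)c(-c2ccc(OCc3ccc(Cl)cc3Cl)c(CC=C)c2)c1`: > 50000 nM
Compound 3 `C=CCc1ccc(OCc2c(Cl)cccc2Cl)c(-c2ccc(OCc3c(Cl)cccc3Cl)c(CC=C)c2)c1`: > 50000 nM

Among the compounds with values here, in a functional assay on I10 cells (Mus musculus) for inhibition, read by MTT assay, with a stated time of 72 h (a higher number here means a weaker inhibitor, a lower number a stronger inhibitor), compound 1 gives 21800 nM, the only number among the three measured compounds. For compound 2 the value > 50000 nM is a limit of the assay. For compound 3 the value > 50000 nM is likewise a limit. Both limits sit at the limit of > 50000 nM in this assay, at which 2 of the 3 values shown sit. Within the data shown here, no step between measured compounds is available.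

Compound 4 `C=CCc1ccc(OCc2ccccc2)c(-c2ccc(OCc3ccccc3)c(CC=C)c2)c1` differs from compound 1 by benzyl in place of hydrogen on an oxygen on an aromatic ring. Compound 2 and compound 3 each carry two ether groups and neither gives a number, so for compound 4 a step toward weaker inhibition is expected in this assay, of moderate size and possibly beyond the scatter. Compound 4 is therefore estimated at 45000 nM, within 20000 nM to 100000 nM. The expected step is a 2.1-fold higher number from compound 1 to compound 4 (0.31 log units; beyond the scatter).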

Compound 4, half-maximal inhibitory concentration: > 50000 nM
Compound 4 gave a limit, no number (the forecaster's own chance of this, stated with the estimate: 50%); at least 1.1-fold (0.04 log units) between middle value and limit.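

In this assay, within the data shown here, benzyl in place of hydrogen on an oxygen on an aromatic ring gives an at least 2.2-fold higher number from compound 1 to compound 4 (0.36 log units; beyond the scatter) as the first readable step at this position. Of the compounds shown, only compound 1 keeps the hydroxy, and only compound 1 gives a number. The value of compound 4 is a limit, so the step has a floor and no measured size: the limit of > 50000 nM in this assay, at which 3 of the 4 values shown sit.

As far as these compounds go, whether methyl or an aminoethyl chain on this oxygen would give a number in this assay remains open. Also open, from the compounds shown here alone, is how a carboxylic acid on the same oxygen chain would read.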